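From 4-fluorophenyl to 2-methylphenyl on selenium

The compounds below may be only part of what the source reports. "The series", "measured", "known", "first", "only" and "open" are said of these compounds alone.

Among the compounds with values here, in a functional assay on Jurkat cells (Homo sapiens) for cytotoxicity, read by MTT assay, with a stated time of 24 h (a higher number here means that more compound is needed for the effect, a lower number that less compound is needed), compound 1 (`CCOC(=O)c1cc([Se]c2ccc(F)cc2)c2cc(OC)ccc2n1`) gives 134000 nM, the higher of the two numbers measured so far. Compound 2 (`CCOC(=O)c1cc([Se]c2ccc3ccccc3c2)c2cc(OC)ccc2n1`) gives 50700 nM, a lower number by more than the scatter. Still unmeasured is compound 3 (`CCOC(=O)c1cc([Se]c2ccccc2C)c2cc(OC)ccc2n1`), which keeps the core of compound 1 and carries 2-methylphenyl in place of 4-fluorophenyl on a selenium. Within the data shown here, no measured pair differs in one place only, so no direct step guides the expectation. Among the measured compounds shown here, with compound 1 at the higher of only two numbers, a small move towards a lower number in this assay is expected, probably within the scatter. The expected step is a 1.3-fold lower number from compound 1 to compound 3 (0.13 log units; within the scatter). For compound 3 the estimated value is 100000 nM, with an expected range from 45000 nM to 220000 nM.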

Compound 3, half-maximal effective concentration: 14900 nM
Compound 3: the middle estimate sits 6.7-fold (0.83 log units) above what was measured, and the stated range ends above it.
By their numbers in this assay, from the lowest: compound 3; then compound 2; then compound 1.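

In this assay, 2-methylphenyl in place of 4-fluorophenyl on a selenium gives a 9.0-fold lower number from compound 1 to compound 3 (0.95 log units; beyond the scatter), so this position responds strongly to a change of aryl group, even though the group that enters matches the one that leaves in its count of heavy atoms and its single aromatic ring of carbon only. The printed values also put compound 3 at 14900 nM, under compound 2 at 50700 nM, so a naphthalene-type group is not needed for a number in this range. No measurement at hand gives a reason for this step.

Going by these compounds, the step removes the fluorine and adds the methyl together, so the share of each remains unknown. Plain phenyl, 4-methylphenyl and 2-fluorophenyl on the same selenium would separate the two, and 2-ethylphenyl would show whether a longer chain carries the trend further.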